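The source may hold more compounds than are shown below. What is called first, only, known or untested is meant among the compounds shown, and "the series" means these compounds.

Measured so far:
compound 1, `Cc1cc(C#N)cc(C)c1Oc1ccnc(Nc2ccc(CN3CCN(S(=O)(=O)C4CC4)CC3)cc2)n1` — 4430 nM in an ADME assay on MT4 cells (Homo sapiens) for cytotoxicity, read by MTT assay; on this read-out higher numbers stand for lower toxicity in this test and lower numbers for higher toxicity in this test
compound 2, `Cc1cc(C#N)cc(C)c1Oc1ccnc(Nc2ccc(CN3CCN(S(=O)(=O)N(C)C)CC3)cc2)n1` — 4460 nM in this assay

Among the measured compounds shown here, compound 2 is one of two compounds measured here, and a 1.0-fold higher number from compound 1 to compound 2 (0.00 log units; within the scatter) places compound 2 together with compound 1 within the scatter. Compound 3, `Cc1cc(/C=C/C#N)cc(C)c1Oc1ccnc(Nc2ccc(CN3CCN(S(=O)(=O)N(C)C)CC3)cc2)n1`, carries 2-cyanoethenyl in place of cyano on an aromatic carbon. For the measured compounds named here, the only measured step, a 1.0-fold higher number from compound 1 to compound 2 (0.00 log units; within the scatter), concerns the group on the sulfonyl sulfur and not this aromatic ring, so no measured step bears on the change to compound 3. The step of a 1.0-fold higher number from compound 2 to compound 3 (0.00 log units; within the scatter) is therefore expected to stay within the scatter. Compound 3 is expected to give 4500 nM, with a range from 2000 nM to 10000 nM.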

Compound 3, half-maximal cytotoxic concentration: 3070 nM
Compound 3: the middle estimate sits 1.5-fold (0.17 log units) above what was measured; the range from low to high includes it.
By their numbers in this assay, from the lowest: compounds 3, 1 and 2 (each within the scatter of the next).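

In this assay, 2-cyanoethenyl in place of cyano on the aromatic carbon gives a 1.5-fold lower number from compound 2 to compound 3 (0.16 log units; within the scatter) as the only step among these compounds at this position. The ring position therefore takes a group of four heavy atoms in place of one of two, and the read-out stays within the scatter. Nothing available here speaks to the reason for this result.

From the compounds shown here alone, whether an amine, a carboxylic acid or a saturated 2-cyanoethyl chain at this position would also stay within the scatter remains open. Also open, going by these compounds, is whether the same change reads alike with cyclopropyl on the sulfonyl sulfur.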